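From Compound 3 to Compound 4: A Smaller Group

The source may hold more compounds than are shown below. What is called first, only, known or untested is meant among the compounds shown, and "the series" means these compounds.

In a functional assay on HeLa cells (Homo sapiens) for inhibition, read by MTT assay, with a stated time of 48 h (a lower number here means a stronger inhibitor, a higher number a weaker inhibitor), compound 1 (`CCOC(=O)C1=C(NN=C(C(C)=O)C(C)=O)Nc2[nH]nc(C)c2C1c1ccc(N(C)C)cc1`) gives 17000 nM and compound 2 (`CCOC(=O)C1=C(N/C=N/c2nnc(S(N)(=O)=O)s2)Nc2[nH]nc(C)c2C1c1ccc(N(C)C)cc1`) gives 26300 nM while compound 3 (`CCOC(=O)C1=C(N/N=C(/C(=O)Br)c2ccc(Br)cc2)Nc2[nH]nc(C)c2C1c1ccc(N(C)C)cc1`) gives 68500 nM as the highest number of the three. The change to compound 4 (`CCOC(=O)C1=C(N/N=C(/Br)c2ccccc2)Nc2[nH]nc(C)c2C1c1ccc(N(C)C)cc1`) is a group of 9 heavy atoms (7 carbon, 1 nitrogen, 1 bromine; one six-membered aromatic ring of carbon only) in place of a group of 12 heavy atoms (8 carbon, 1 nitrogen, 1 oxygen, 2 bromine; one six-membered aromatic ring of carbon only), on an amine nitrogen with the rest of the structure unchanged. Two measured steps lead to compound 3 and both are modest: a 4.0-fold higher number from compound 1 to compound 3 (0.61 log units; beyond the scatter) and a 2.6-fold higher number from compound 2 to compound 3 (0.42 log units; beyond the scatter) at that same amine nitrogen. The third, a 1.5-fold higher number from compound 1 to compound 2 (0.19 log units; within the scatter) stays within the scatter. Going by the values given here, no measured step isolates this exact change, so the expectation is loose. A modest move toward lower numbers is expected in this assay and is estimated as a 1.8-fold lower number from compound 3 to compound 4 (0.26 log units; within the scatter) from these steps. Compound 4 is estimated at 38000 nM with an expected range of 14000 nM to 85000 nM in that read-out.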

Compound 4, half-maximal inhibitory concentration: 75700 nM
Beside the measured number, compound 4's estimate is 2.0-fold (0.30 log units) below it; low and high end bracket the measured number.
By their numbers in this assay, from the lowest: compounds 1 and 2 (each within the scatter of the next); then compounds 3 and 4 (each within the scatter of the next).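

In this assay, exchanging the group of 12 heavy atoms for the group of 9 heavy atoms on this amine nitrogen leaves the number unmoved (a 1.1-fold higher number from compound 3 to compound 4 (0.04 log units; within the scatter)), although the change drops a carbonyl and a bromine together. Compound 4 stays clear of the two compounds without a six-membered aromatic ring of carbon in this group (a 2.9-fold higher number from compound 2 to compound 4 (0.46 log units; beyond the scatter); a 4.5-fold higher number from compound 1 to compound 4 (0.65 log units; beyond the scatter)), as compound 3 does. No evidence on why is available.

On these data alone, the separate effects of the carbonyl and the bromine remain open. So does whether an amine or a carboxylic acid on that ring would shift the number.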